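From 4-fluorophenyl to 2,4-dichlorophenyl

The source may report more compounds than this note shows. Statements on the series, on what has been measured and on what is new or still open speak of the compounds shown alone.

In a functional assay on HeLa cells (Homo sapiens) for cytotoxicity, read by MTT assay, with a stated time of 24 h (a higher number here means a weaker inhibitor, a lower number a stronger inhibitor), compound 2 `COc1cc(/C=C2\CN(C)C/C(=C\c3ccc(F)cc3)C2=O)cc(OC)c1OC` gives 7250 nM and compound 1 `COc1cc(/C=C2\CN(C)C/C(=C\c3ccc(F)cc3)C2=O)cc(OC)c1` gives 10200 nM with the two values within the scatter of each other. Among the measured compounds shown here, the one measured step of a 1.4-fold lower number from compound 1 to compound 2 (0.15 log units; within the scatter) is methoxy in place of hydrogen on an aromatic carbon, a different change from the one ahead. For the measured compounds named here, compound 3 `COc1cc(/C=C2\CN(C)C/C(=C\c3ccc(Cl)cc3Cl)C2=O)cc(OC)c1OC` carries 2,4-dichlorophenyl in place of 4-fluorophenyl on a double-bonded chain carbon bound to a double-bonded ring carbon and no measured step covers that exchange. The expected step of a 1.2-fold lower number from compound 2 to compound 3 (0.08 log units; within the scatter) in this assay is therefore none beyond the scatter. Compound 3 is estimated at 6000 nM with an expected range from 2500 nM to 14000 nM in this measurement.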

Compound 3, half-maximal inhibitory concentration: > 20000 nM
Compound 3: only a limit was reported (the forecaster's own chance of this, stated with the estimate: 5%); middle value at least 3.3-fold (0.52 log units) from the limit.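

In this assay, 2,4-dichlorophenyl in place of 4-fluorophenyl gives an at least 2.7-fold higher number from compound 2 to compound 3 (0.44 log units; beyond the scatter), whereas the earlier methoxy exchange stayed within the scatter. Among the compounds shown here, this is the first sign that the group on the double-bonded chain carbon can shift the read-out, here toward a weaker inhibitor. The reading for compound 3 is a limit and not a number: the limit of > 20000 nM in this assay, at which 1 of the 3 values shown sits.

As far as these compounds go, how far compound 3 lies past its limit remains open, as does the separate contribution of each chlorine to the step. Also open, from the compounds shown here alone, is how an amine or a carboxylic acid on this phenyl ring would read.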